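This account rests on a few compounds, and the source may have more. Where it says the series, first, only, none or still open, it means among the compounds named here.

In a functional assay on Huh-7 cells (Homo sapiens) for inhibition, read by CCK-8 assay, with a stated time of 72 h (a higher number here means a weaker inhibitor, a lower number a stronger inhibitor), compound 1 `Cc1ccc(NS(=O)(=O)c2cccc(CCCCCCNC(=O)/C=C/c3cccnc3)c2)cc1` gives 6.92 nM, and compound 2 `CCc1ccc(NS(=O)(=O)c2cccc(CCCCCCNC(=O)/C=C/c3cccnc3)c2)cc1` gives 34.6 nM. Compound 2 therefore holds the higher of the two numbers and is the weaker inhibitor of the pair. Compound 3 `CC(C)(C)c1ccc(NS(=O)(=O)c2cccc(CCCCCCNC(=O)/C=C/c3cccnc3)c2)cc1` keeps the shared core and changes one group: tert-butyl in place of ethyl on an aromatic carbon. In words, tert-butyl stands in place of ethyl on an aromatic carbon. Among the compounds with values here, only one measured step bears on this change, a 5.0-fold higher number from compound 1 to compound 2 (0.70 log units; beyond the scatter), where the group at the same place went from methyl to ethyl. That single step is thin evidence, but it suggests that a further enlargement of this group will raise the number again, by a similar or somewhat smaller amount. The expected change is a 2.6-fold higher number from compound 2 to compound 3 (0.42 log units; beyond the scatter). For compound 3 the estimated value is 90 nM, with an expected range from 25 nM to 300 nM.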

Compound 3, half-maximal inhibitory concentration: 163 nM
Compound 3: the middle estimate sits 1.8-fold (0.26 log units) below what was measured, and the stated range covers the measured number.
By their numbers in this assay, from the lowest: compound 1; then compound 2; then compound 3.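

With tert-butyl at this place on the aromatic ring, the rise seen on going from methyl to ethyl continues in this assay: there is a 4.7-fold higher number from compound 2 to compound 3 (0.67 log units; beyond the scatter), so the change from ethyl to a larger branched group costs about as much as the earlier one-carbon step, and both steps rank as modest. Across the whole series, there is a 24-fold higher number from compound 1 to compound 3 (1.37 log units; beyond the scatter), a large step, and the three compounds line up in the order methyl, ethyl, tert-butyl, with none going against it. No measurement at hand gives a reason for this order. The compounds shown leave open whether an unbranched propyl chain would follow the same order as tert-butyl, or whether the order depends on the number of carbons alone. They also leave open how a bare hydrogen, a methoxy group or a carboxylic acid at this place would compare with methyl.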